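Propyl for Isopropyl on a Weakly Active Fused Core

The compounds below may be only part of what the source reports. "The series", "measured", "known", "first", "only" and "open" are said of these compounds alone.

Compound 3 `CSc1nncc2c(C)nc(C(C)C)n12` was tested in a functional assay for inhibition, with Homo sapiens as the target; a higher number here means a weaker inhibitor, a lower number a stronger inhibitor. In this assay compound 3 gives only a limit, > 48000 nM, and not a number. Two other compounds were measured the same way. Compound 1 `CCCc1nn(C)c(=O)n2c(CCC)nc(C)c12` gives 18000 nM in this assay. Compound 2 `CCCc1nc(C)c2cnnc(SCC(=O)OCC)n12` gives only a limit in this assay, > 48000 nM. Compound 3 therefore stands at the limit, the same limit at which two of the three values sit (the limit of > 48000 nM in this assay, at which 2 of the 3 values shown sit), while compound 1 alone returns a number.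

Compound 4 `CCCc1nc(C)c2cnnc(SC)n12` has not yet been measured. It differs from compound 3 in one respect: propyl in place of isopropyl on an aromatic carbon. Among the compounds with values here, no measured pair shows this change on its own, so no step size is known from the data. The expectation rests on what is seen. Compound 3 sits at the limit with > 48000 nM. Compound 2, which also carries a propyl group, sits at the limit with > 48000 nM. The step from compound 3 to compound 4 is therefore expected to be a step that the limit leaves unreadable from compound 3 to compound 4, none beyond the scatter. Compound 4 is estimated at 60000 nM, with a range from 20000 nM to 200000 nM, and this assay is expected most likely to report again only a limit for compound 4.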

Compound 4, half-maximal inhibitory concentration: > 48000 nM
Compound 4: no number, only a limit; the forecaster's own chance of this, stated with the estimate: 70%; the middle value is on the limit's open side.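

In this assay compound 4 gives only a limit, > 48000 nM, and not a number, so its steps from compound 3 and from compound 2 cannot be read. Compound 4 joins the shared limit: the limit of > 48000 nM in this assay, at which 3 of the 4 values shown sit. The compounds shown leave open whether propyl in place of isopropyl, or hydrogen in place of ethoxycarbonyl, changes inhibition at all.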